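Shared core: effect of removing the ring substituent

The compounds below may be only part of what the source reports. "The series", "measured", "known", "first", "only" and "open" are said of these compounds alone.

Two compounds share one core and differ only in what is attached to the six-membered aromatic ring of that core. Compound 1 `C=CC(C)(C)c1[nH]c2ccc(C[C@H]3OC(C)(C)OC3(C)C)cc2c1/C=C1\NC(=O)[C@H](C)NC1=O` is one of them; in a functional assay (on this read-out lower numbers stand for stronger inhibition and higher numbers for weaker inhibition), compound 1 gives 88000 nM. Compound 2 `C=CC(C)(C)c1[nH]c2c(C[C@@H](O)C(C)(C)Cl)cccc2c1/C=C1\NC(=O)[C@H](C)NC1=O` is the other; in this assay compound 2 gives 77000 nM. Compound 2 holds the lowest of the two numbers, yet its gap to compound 1 is within the usual scatter, so the two cannot be told apart on these data. Both sit at very weak inhibition.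

Compound 3 `C=CC(C)(C)c1[nH]c2ccccc2c1/C=C1\NC(=O)[C@H](C)NC1=O` has not been measured in this assay. It differs from compound 2 in a single place: hydrogen in place of 3-chloro-2-hydroxy-3-methylbutyl on an aromatic carbon. Among the compounds with values here, no step between measured compounds is known, so the size of the step to compound 3 rests on the two values alone. Since the substituent on compound 2, giving 77000 nM, and the different substituent on compound 1, giving 88000 nM, leave the read-out in the same weak range, no move beyond the scatter is expected from its removal, with a slight lean toward weaker inhibition. The expected step from compound 2 to compound 3 is a 1.3-fold higher number from compound 2 to compound 3 (0.11 log units; within the scatter). For compound 3 the estimated value in this assay is 100000 nM, within an expected range from 30000 nM to 300000 nM.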

Compound 3, half-maximal inhibitory concentration: 103000 nM
Compound 3: the middle estimate sits 1.0-fold (0.01 log units) below what was measured; the range from low to high includes it.
By their numbers in this assay, from the lowest: compounds 2, 1 and 3 (each within the scatter of the next).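

In this assay, hydrogen in place of 3-chloro-2-hydroxy-3-methylbutyl on an aromatic carbon gives a 1.3-fold higher number from compound 2 to compound 3 (0.13 log units; within the scatter), and hydrogen in place of (2,2,5,5-tetramethyl-1,3-dioxolan-4-yl)methyl gives a 1.2-fold higher number from compound 1 to compound 3 (0.07 log units; within the scatter). The two substituted compounds could earlier be read only against each other; compound 3 now supplies the hydrogen reference, and neither substituent can be told apart from it on this read-out, so no gain or loss can be assigned to either group, and the very weak inhibition is already present in the shared core without any substituent on this ring. No supporting data bear on why these steps stay so small.

Whether an amine, a carboxylic acid or a plain longer alkyl chain on this aromatic carbon would move the number beyond the scatter remains open, since both groups shown are branched oxygen-bearing chains or rings. Also open, from the compounds shown here alone, is whether any substituent on this ring can shift the read-out at all, or whether a change elsewhere on the shared core would be needed first.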